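Moving the furan attachment on a weakly active compound

The source may hold more compounds than are shown below. What is called first, only, known or untested is meant among the compounds shown, and "the series" means these compounds.

In a functional assay on A549 cells (Homo sapiens) for inhibition (on this read-out higher numbers stand for weaker inhibition and lower numbers for stronger inhibition), compound 1 (`FC(F)(F)Oc1cccc(/C=C\c2ccc3ccccc3c2)c1`) gives 3500 nM as a measured number. Compound 2 (`C(=C/c1ccco1)\c1ccc2ccccc2c1`) reads > 5000 nM and this is a limit of the assay, not a number. Compound 3 (`C(=C\c1ccco1)\c1ccc2ccccc2c1`) reads > 5000 nM and this is a limit too. Compound 4 (`C(=C/c1ccc2ccccc2c1)\c1ccoc1`) has furan-3-yl in place of furan-2-yl on a double-bonded chain carbon bound to a double-bonded chain carbon and is still unmeasured. For the measured compounds named here, the only measured step that bears on this is a step that the two limits leave unreadable from compound 2 to compound 3 and it concerns configuration alone, so it offers no size to carry over. The expected step is a step that the limit leaves unreadable from compound 2 to compound 4 and no direction beyond the scatter is foreseen. For compound 4 the estimate is 6000 nM with 3000 nM to 12000 nM as the likely span.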

Compound 4, half-maximal inhibitory concentration: > 5000 nM
Compound 4 was reported as a limit (the forecaster's own chance of this, stated with the estimate: 65%); the middle value is on the limit's open side.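

In this assay, for the compounds shown here, compound 2 and compound 4 both read as limits, not numbers, and no step between them can be read. As far as these compounds go, whether furan-3-yl and furan-2-yl differ in inhibition at all remains open.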